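The compounds below may be only part of what the source reports. "The series", "measured", "known", "first", "only" and "open" are said of these compounds alone.

In a functional assay on B16 cells (Mus musculus) for inhibition (on this read-out lower numbers stand for stronger inhibition and higher numbers for weaker inhibition), three compounds sharing one core have been measured. Compound 1 (`COc1ccc(C2=C(c3cc(OC)c(OC)c(OC)c3)C(=O)CC2)cc1`) stands at 0.015 ug/mL and compound 2 (`COc1ccc(C2=C(c3cc(OC)c(OC)c(OC)c3)C(=O)C=C2)cc1`) at 0.011 ug/mL with no gap beyond the scatter between them. Compound 3 (`COc1ccc(C2=C(c3cc(OC)c(OC)c(OC)c3)C(O)CC2)cc1`) reads 0.039 ug/mL and holds the highest of the three numbers, beyond the scatter from both of the others.

Compound 4 (`COc1ccc(C2=C(c3cc(OC)c(OC)c(OC)c3)CCC2)cc1`) has not yet been measured. It differs from compound 3 in one place (hydrogen in place of hydroxy on a saturated ring carbon) with hydrogen in place of hydroxy on a saturated ring carbon. For the measured compounds named here, no two measured compounds differ in one place only, so the size of this step can only be judged indirectly. Going by the values given here, compound 3 is the only measured compound with a hydroxy group, and compound 1 at 0.015 ug/mL and compound 2 at 0.011 ug/mL both lie lower without one. Compound 4 lacks the hydroxy group as well as the carbonyl that those two carry, so a small move towards a lower number is expected in this assay and it may not exceed the scatter. The step expected is a 1.6-fold lower number from compound 3 to compound 4 (0.19 log units; within the scatter) on this estimate. For compound 4 the estimated value is 0.025 ug/mL (expected range 0.007 ug/mL to 0.09 ug/mL).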

Compound 4, half-maximal inhibitory concentration: > 1 ug/mL
Compound 4 was reported as a limit (the forecaster's own chance of this, stated with the estimate: 2%); at least 40-fold (1.60 log units) between middle value and limit.
By their numbers in this assay, from the lowest: compounds 2 and 1 (each within the scatter of the next); then compound 3. At a limit, above all of these: compound 4.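

In this assay, for the compounds shown here, replacing hydroxy with hydrogen on a saturated ring carbon gives an at least 25-fold higher number from compound 3 to compound 4 (1.40 log units; beyond the scatter), the first step that can be read at a single place. Compound 4 gives > 1 ug/mL, which is a limit and not a number, so the step has a floor but no known full size: (the limit of > 1 ug/mL in this assay, at which 1 of the 4 values shown sits). The result shows that this ring carbon is not indifferent to what it carries, as compound 3 at 0.039 ug/mL with hydroxy and compound 1 at 0.015 ug/mL with a carbonyl both give readings within the range of this assay, whereas hydrogen alone on that carbon does not.

The compounds shown do not settle whether oxygen itself is what counts at this ring carbon, since they include no amine, fluorine or methyl there to set against hydroxy and hydrogen. They also leave open how an ether such as ethoxy or an ester such as acetoxy at this carbon would read, and so whether the free hydroxy hydrogen plays any part.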